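A chloro swap on a very stable compound

The source may report more compounds than this note shows. Statements on the series, on what has been measured and on what is new or still open speak of the compounds shown alone.

Compound 1 `COc1ccc(-c2c(C)nc3c(N4CC[C@@H](NC(C)=O)C4)cc(C)nn23)cc1OC` was tested in an ADME assay on microsomes from liver (Mus musculus) for metabolic stability, read by LC-MS, with NADPH named in the record, with a stated time of 60 min, tested at 1 uM, in the absence of a further agent; on this read-out higher numbers stand for a more stable compound and lower numbers for a less stable compound. There, compound 1 gives > 95%, a limit of the assay and not a number. Compound 2 `CC(=O)N[C@@H]1CCN(c2cc(C)nn3c(-c4ccccc4)c(C)nc23)C1` gives > 95%, also a limit. Compound 3 `CC(=O)N[C@@H]1CCN(c2cc(C)nn3c(-c4ccc(C(F)(F)F)cc4)c(C)nc23)C1` gives > 95%, again a limit.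

Compound 4 `COc1ccc(-c2c(C)nc3c(N4CC[C@@H](NC(C)=O)C4)cc(Cl)nn23)cc1OC` alters compound 1 in one place: chloro in place of methyl on an aromatic carbon. This is chloro in place of methyl on an aromatic carbon, next to the ring nitrogen. The measured steps lie elsewhere and offer no size to carry over: a step that the two limits leave unreadable from compound 1 to compound 2, a step that the two limits leave unreadable from compound 1 to compound 3 and a step that the two limits leave unreadable from compound 2 to compound 3. Going by the values given here, no measured pair tests this methyl, so the forecast is uncertain. Among the compounds with values here, the only guide is that compound 1 stands with its neighbours at the limit of > 95% in this assay, at which 3 of the 3 values shown sit. The expected change is small, downward if at all, and no larger than the usual scatter: a number at least 3 percentage points lower from compound 1 to compound 4 (that floor lies within the scatter). For compound 4 the estimated value is 92%, with an expected range from 75% to 100%.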

Compound 4, percent of the compound remaining: > 95%
Compound 4 gave a limit, no number; the forecaster's own chance of this, stated with the estimate: 50%; middle value at least 3 percentage points away from the limit.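

Going by these compounds alone, compound 4 gives > 95% in this assay, a limit and not a number, so no step from compound 1 to it can be read. Whether chloro and methyl differ here at all stays open, as the compounds shown share one ceiling: the limit of > 95% in this assay, at which 4 of the 4 values shown sit.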